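From Sec-Butyl to Cyclohexyl on the Amine Nitrogen

A few compounds are considered here, and "the series" means these few. Any claim that something is new, unique, unknown or untested is made for them only; others in the source may bear on it.

Measured so far:
compound 1, `CC(C)CNC(=C\C(=O)/C=C/c1ccc(O)cc1)/C=C/c1ccc(O)cc1`, 100%
compound 2, `CCC(C)NC(=C\C(=O)/C=C/c1ccc(O)cc1)/C=C/c1ccc(O)cc1`, 102%

Two compounds share one core and differ only in the group on an amine nitrogen. In a functional assay on Caco-2 cells (Homo sapiens), read by fluorescence, tested at 1 uM (a lower number here means a stronger effect, a higher number a weaker effect of the compound at the concentration tested), compound 1 gives 100%, and compound 2 gives 102%. Among the compounds with values here, the single change between them gave a number 2 percentage points higher from compound 1 to compound 2 (within the scatter), so the two numbers cannot be told apart, and compound 2 stands at the same level as compound 1. At the concentration tested, neither compound shows an effect that rises above the usual scatter of this measurement.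

Compound 3, `O=C(/C=C(/C=C/c1ccc(O)cc1)NC1CCCCC1)/C=C/c1ccc(O)cc1`, carries the next change: cyclohexyl in place of sec-butyl on an amine nitrogen. Within the data shown here, the only measured step that bears on it is the exchange of one small alkyl group for another on the same nitrogen, a number 2 percentage points higher from compound 1 to compound 2 (within the scatter), and that step was within the scatter. On these data alone, a ring in place of a chain on this nitrogen is untested, so no direction can be read from the data. The expected step is therefore a number 1 percentage points lower from compound 2 to compound 3 (within the scatter), nothing beyond the scatter. Compound 3 is estimated at 101%, with a range from 90% to 112%.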

Compound 3, a percentage reported as activity, at one concentration (the size of the read-out at that concentration, not a potency): 97%
Compound 3: middle estimate off by 4 percentage points, on the high side; low and high end bracket the measured number.
By their numbers in this assay, from the lowest: compounds 3, 1 and 2 (each within the scatter of the next).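

In this assay, the first ring at this position, a cyclohexyl group on the amine nitrogen, gives a step against each open-chain group: (a number 5 percentage points lower from compound 2 to compound 3 (within the scatter)) against sec-butyl and (a number 3 percentage points lower from compound 1 to compound 3 (within the scatter)) against isobutyl. Both steps stay within the scatter, so this change reveals no difference, even though it goes beyond swapping one small chain for another: the 4 carbon atoms of sec-butyl give way to the 6 carbon atoms of cyclohexyl, and a six-membered non-aromatic ring replaces an open chain. Nothing available explains why these three compounds cannot be told apart, so the result stands as an observation only.

The compounds shown cover only groups made of carbon alone on this nitrogen, so it remains open whether a group carrying a carboxylic acid or a further amine, or a benzyl group or a much longer chain, would produce a step beyond the scatter. They also leave open what happens when the shared core changes, for example when the hydroxyl groups on its two aromatic rings are replaced by methoxy groups.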